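The source may report more compounds than this note shows. Statements on the series, on what has been measured and on what is new or still open speak of the compounds shown alone.

Compound 1 `COc1cc(Cl)cc(-c2nn(-c3cccc(NC(=O)Nc4ccc(Cl)c(C(F)(F)F)c4)c3)cc2-c2ccncc2)c1`: 80%
Compound 2 `COc1cc(Cl)cc(-c2nn(-c3cccc(NC(=O)Nc4cc(C(F)(F)F)cc(C(F)(F)F)c4)c3)cc2-c2ccncc2)c1`: 24%
Compound 3 `COc1cc(Cl)cc(-c2nn(-c3cccc(NC(=O)Nc4ccc(Cl)c(Cl)c4)c3)cc2-c2ccncc2)c1`: 91%

These three compounds share one core and differ only in the group attached to the amide-type nitrogen. In a functional assay on COLO 205 cells (Homo sapiens) for inhibition, read by sulforhodamine B assay, with a stated time of 48 h, tested at 1 uM (a lower number here means a stronger effect, a higher number a weaker effect of the compound at the concentration tested), compound 3 gives the highest of the three numbers; compound 1 sits closest to it, and compound 2 lies far lower. Compound 4 `COc1cc(Cl)cc(-c2nn(-c3cccc(NC(=O)Nc4cccc(C(F)(F)F)c4)c3)cc2-c2ccncc2)c1` has not yet been measured. It differs from compound 3 in one place: 3-(trifluoromethyl)phenyl in place of 3,4-dichlorophenyl on an amide-type nitrogen. Going by the values given here, the only measured step touching this part of the molecule is a number 11 percentage points higher from compound 1 to compound 3 (beyond the scatter), a modest rise for chloro in place of trifluoromethyl. Compound 4 keeps a trifluoromethyl, as compound 1 does, but has no chloro at all, and compound 2, carrying two trifluoromethyls, gives a much lower number in this assay than compound 1. Among the compounds with values here, no measured step removes a chloro outright, so the expectation is loosely held: compound 4 is expected to give a somewhat lower number than compound 3, a step of a number 19 percentage points lower from compound 3 to compound 4 (beyond the scatter). The estimate for compound 4 is 72%, expected to fall between 48% and 92%.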

Compound 4, a percentage reported as activity, at one concentration (the size of the read-out at that concentration, not a potency): 79%
Compound 4: middle estimate off by 7 percentage points, on the low side; low and high end bracket the measured number.
By their numbers in this assay, from the lowest: compound 2; then compounds 4 and 1 (each within the scatter of the next); then compound 3.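

With 3-(trifluoromethyl)phenyl on the amide-type nitrogen, the added chloro of compound 1 counts for little in this assay: hydrogen in place of that chloro gives a number 1 percentage points lower from compound 1 to compound 4 (within the scatter). The second trifluoromethyl counts for far more, since hydrogen in its place gives a number 55 percentage points higher from compound 2 to compound 4 (beyond the scatter), so the low number of compound 2 goes with that extra group and not with the single trifluoromethyl it shares with compound 4. Against that large step, 3-(trifluoromethyl)phenyl in place of 3,4-dichlorophenyl is a modest change, giving a number 12 percentage points lower from compound 3 to compound 4 (beyond the scatter).

On these data alone, whether a nitrile or a methyl ester in place of the second trifluoromethyl would give a similarly low number stays open. No measurement at hand explains why that one group carries so large a step.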